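Aryl thioether variation in a nucleoside series

The source may hold more compounds than are shown below. What is called first, only, known or untested is meant among the compounds shown, and "the series" means these compounds.

Three compounds share one core and differ only in the arylthio group attached to it. Compound 1 `Cc1ccc(CSc2ncnc3c2ncn3[C@@H]2O[C@H](CO)[C@@H](O)[C@H]2O)cc1` gives 457 nM in an assay on isolated protein for binding affinity to Equilibrative nucleoside transporter 1 (Homo sapiens); on this read-out higher numbers stand for weaker inhibition and lower numbers for stronger inhibition. Compound 2 `OC[C@H]1O[C@@H](n2cnc3c(CSc4ccccc4I)ncnc32)[C@H](O)[C@@H]1O` gives 282 nM in this assay, and compound 3 `OC[C@H]1O[C@@H](n2cnc3c(CSc4cccc(I)c4)ncnc32)[C@H](O)[C@@H]1O` gives 245 nM in this assay. Compound 3 holds the lowest of the three numbers, yet the gaps to the others are small: a 1.9-fold lower number from compound 1 to compound 3 (0.27 log units; within the scatter) and a 1.2-fold lower number from compound 2 to compound 3 (0.06 log units; within the scatter), both within the scatter, so no order among the three is established.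

Compound 4 `COc1ccc(SCc2ncnc3c2ncn3[C@@H]2O[C@H](CO)[C@@H](O)[C@H]2O)cc1` is not yet measured. It differs from compound 3 by 4-methoxyphenyl in place of 3-iodophenyl on a sulfur. The measured steps that bear on this change are the exchanges among the aryl groups on the sulfur: a 1.6-fold lower number from compound 1 to compound 2 (0.21 log units; within the scatter), a 1.9-fold lower number from compound 1 to compound 3 (0.27 log units; within the scatter) and a 1.2-fold lower number from compound 2 to compound 3 (0.06 log units; within the scatter). Every such exchange has so far left the number within the scatter, so no step beyond the scatter is expected from compound 3 to compound 4 in this assay. The step expected is a 1.3-fold higher number from compound 3 to compound 4 (0.12 log units; within the scatter). For compound 4 in this assay the estimate is 320 nM, with a range from 130 nM to 800 nM.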

Compound 4, half-maximal inhibitory concentration: 617 nM
For compound 4 the middle estimate is 1.9-fold (0.29 log units) below the measured one, within the range that was stated.
By their numbers in this assay, from the lowest: compounds 3, 2, 1 and 4 (each within the scatter of the next, the first and the last beyond it).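

In this assay, the aryl group on the sulfur is no longer silent: unlike the exchanges among compound 1, compound 2 and compound 3, 4-methoxyphenyl in place of 3-iodophenyl gives a 2.5-fold higher number from compound 3 to compound 4 (0.40 log units; beyond the scatter), and 4-methoxyphenyl in place of 2-iodophenyl gives a 2.2-fold higher number from compound 2 to compound 4 (0.34 log units; beyond the scatter), both modest steps toward weaker inhibition, while the two iodophenyl groups themselves stay within the scatter of each other, with a 1.2-fold lower number from compound 2 to compound 3 (0.06 log units; within the scatter). The change alters several features at once, since iodine leaves, an oxygen with one hydrogen-bond acceptor enters and the substituent's place on the ring differs as well, so these two steps cannot assign the rise to any one of those features. No measurement at hand bears on the reason for the rise.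

On these data alone, whether the step follows the methoxy group or its place on the ring stays open, and 3-methoxyphenyl and 4-iodophenyl on the same sulfur would separate the two. Also open, as far as these compounds go, is how the number responds to an aryl ring carrying an amine or a carboxylic acid, or to a saturated alkyl chain in place of the aryl group.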